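A Single Fluoro Change to Compound 1

This account rests on a few compounds, and the source may have more. Where it says the series, first, only, none or still open, it means among the compounds named here.

In an ADME assay for permeability, using PAMPA, at pH 4 (a higher number here means that the compound crosses the layer faster, a lower number that the compound crosses the layer more slowly), compound 1 (`Cc1[nH]c2ccccc2c(=O)c1Br`) gives 8.19 10^-6 cm/s as the lowest of three measured numbers. Compound 2 (`Cc1[nH]c2ccccc2c(=O)c1/C=C/C(=O)OC(C)(C)C`) gives 105 10^-6 cm/s and compound 3 (`Cc1[nH]c2ccccc2c(=O)c1/C=C/c1ccccc1`) gives 222 10^-6 cm/s on the same read-out. Compound 4 (`Cc1[nH]c2ccc(F)cc2c(=O)c1Br`) awaits measurement and differs from compound 1 by one change, fluoro in place of hydrogen on an aromatic carbon. Among the compounds with values here, the only measured step (a 2.1-fold higher number from compound 2 to compound 3 (0.33 log units; beyond the scatter)) puts phenyl in place of tert-butoxycarbonyl, a modest step that involves different groups and offers little guidance here. Within the data shown here, no measured compound shows a fluoro change, so no step beyond the scatter is expected in this assay, in either direction. The expected step is small (a 1.2-fold higher number from compound 1 to compound 4 (0.09 log units; within the scatter)). Compound 4 is expected at 10 10^-6 cm/s (estimated range 4.5 10^-6 cm/s to 22 10^-6 cm/s).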

Compound 4, apparent permeability: 16.2 10^-6 cm/s
Beside the measured number, compound 4's estimate is 1.6-fold (0.21 log units) below it; the measured number falls inside the stated range.
By their numbers in this assay, from the lowest: compounds 1 and 4 (each within the scatter of the next); then compound 2; then compound 3.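

In this assay, fluoro in place of hydrogen on this aromatic carbon gives a 2.0-fold higher number from compound 1 to compound 4 (0.30 log units; within the scatter), the first fluoro step among these compounds. This step does not separate compound 4 from compound 1 in this assay, so at this position, on the core of compound 1, swapping hydrogen for fluoro gives no clear difference. Nothing measured here offers an explanation for the size of this step. Still open, as far as these compounds go, is whether chloro, methoxy or an amine on the same aromatic carbon would give a step beyond the scatter. Also open, from the compounds shown here alone, is whether fluoro would give a similar step alongside the phenyl-bearing chain of compound 3.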